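A few compounds are considered here, and "the series" means these few. Any claim that something is new, unique, unknown or untested is made for them only; others in the source may bear on it.

Working notes on the cyanoguanidine series in an assay on membranes from heart (Canis lupus familiaris) for displacement of a labelled ligand from sulfonylurea receptor 2, Kir6.2 (Homo sapiens); a lower number here means a stronger inhibitor, a higher number a weaker inhibitor.

Compound 1, `CCC(C)(C)/N=C(\NC#N)Nc1ccc(S(=O)(=O)N2CCCCC2)cc1`, comes out only as a limit of the assay in this assay: compound 1 gives > 30000 nM. That value sits at the limit of > 30000 nM in this assay, at which 1 of the 2 values shown sits, so compound 1 contributes no number to the series and nothing can be said of its place relative to the others beyond that.

For the measured compounds named here, compound 2, `CC(C)(C)/N=C(\NC#N)Nc1ccc(C#N)cc1`, is the one compound with a measured number here: in this assay compound 2 gives 480 nM. Going by the values given here, with only one number in hand, compound 2 stands alone; there is no measured step against which to set it.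

Compound 3, `CC(C)/N=C(\NC#N)Nc1ccc(C#N)cc1`, is not yet measured. It differs from compound 2 by hydrogen in place of methyl on a saturated chain carbon bound to a double-bonded nitrogen and two saturated chain carbons, which is hydrogen in place of methyl on a saturated chain carbon bound to a double-bonded nitrogen and two saturated chain carbons. Among the compounds with values here, no step of this kind has been measured, so the expectation rests on the single value of compound 2 alone. The step from compound 2 to compound 3 is expected to go toward weaker binding, of moderate size, a 3.1-fold higher number from compound 2 to compound 3 (0.49 log units; beyond the scatter). For compound 3 the estimate is 1500 nM, expected to lie between 500 nM and 6000 nM.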

Compound 3, inhibition constant: 7300 nM
Estimate against measurement, compound 3: 4.9-fold (0.69 log units) below; the whole stated range lies below it.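

In this assay, for the compounds shown here, the tert-butyl to isopropyl change gives a 15-fold higher number from compound 2 to compound 3 (1.18 log units; beyond the scatter), the first measured step. It shows that binding in this series responds strongly to the group at this saturated chain carbon bound to a double-bonded nitrogen: the loss of a single methyl, with the rest of the structure held constant, produces a large shift, which one number and one limit could not reveal. Nothing measured here accounts for the size of this step.

As far as these compounds go, whether a bulkier group at this carbon, such as a cyclohexyl ring or a longer chain, would match or better compound 2 at 480 nM remains open, as does how far the trend runs below isopropyl, for example to an ethyl or methyl group. Also open, from the compounds shown here alone, is whether the same methyl-to-hydrogen change has a step of similar size when the nitrile on the shared core is replaced by another group, such as an amine or a carboxylic acid.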